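A Bromo Substituent on a Weakly Cytotoxic Core

The compounds below may be only part of what the source reports. "The series", "measured", "known", "first", "only" and "open" are said of these compounds alone.

Of the compounds shown here, three built on a shared core have been tested in a functional assay on HCT-116 cells (Homo sapiens) for cytotoxicity, read by MTT assay, with a stated time of 72 h; a lower number here means a stronger inhibitor, a higher number a weaker inhibitor. Compound 1, `CS(=O)(=O)NCCCN(c1nc(C(=O)NCc2ccc(F)cc2)c(O)c2ncccc12)S(C)(=O)=O`, gives 15000 nM. Compound 2, `NCCCNc1c(C(=O)NCc2ccc(F)cc2)ncc2cccnc12`, is recorded only as a limit of > 10000 nM. Compound 3, `N[C@H]1CC[C@H](Nc2c(C(=O)NC3CCCCC3)nc(Br)c3cccnc23)CC1`, is likewise recorded only as a limit of > 10000 nM. Compound 2 thus stands among the two results that are limits rather than numbers, while compound 1 alone carries a finite value; how compound 2 compares with compound 1 cannot be told from what is shown.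

Compound 4, `NCCCNc1c(C(=O)NCc2ccc(F)cc2)nc(Br)c2cccnc12`, differs from compound 2 in one place: bromo in place of hydrogen on an aromatic carbon. No pair of measured compounds that differ in a single place is available, so the size of such a change cannot be read from any shown step in this assay. Since compound 2 sits at the limit of > 10000 nM in this assay, at which 2 of the 3 values shown sit, the step that the limit leaves unreadable from compound 2 to compound 4 is expected to be small, if any, and not clearly beyond the scatter in either direction.

For compound 4 the expected value is 15000 nM. Its range is estimated to run from 5000 nM to 50000 nM, and the result may well again be reported only as a limit.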

Compound 4, half-maximal inhibitory concentration: > 20000 nM
Compound 4 was reported as a limit (the forecaster's own chance of this, stated with the estimate: 60%); at least 1.3-fold (0.12 log units) between middle value and limit.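

In this assay compound 4 is recorded only as a limit, > 20000 nM. Going by these compounds alone, compound 2 is likewise recorded only as a limit, > 10000 nM, so no step from one compound to the other can be read. The compounds shown leave open whether bromo in place of hydrogen on an aromatic carbon changes cytotoxicity at all, and in which direction.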